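The source may hold more compounds than are shown below. What is called first, only, known or untested is meant among the compounds shown, and "the series" means these compounds.

Three compounds share one core and differ only in the sulfonamide-bearing side chain. Compound 1 `O=S(=O)(NCCCNc1nccc(-c2c(-c3cccc(F)c3)nc3sccn23)n1)c1ccc(Br)cc1` gives 7040 nM in a functional assay on A-375 cells (Homo sapiens) for cytotoxicity, read by MTT assay; on this read-out lower numbers stand for stronger inhibition and higher numbers for weaker inhibition. Compound 2 `O=S(=O)(NCCNc1nccc(-c2c(-c3cccc(F)c3)nc3sccn23)n1)c1ccc(F)cc1` gives 9450 nM in this assay, and compound 3 `O=S(=O)(NCCNc1nccc(-c2c(-c3cccc(F)c3)nc3sccn23)n1)c1ccc(Cl)cc1` gives 18600 nM in this assay. Compound 2 stands second highest of the three numbers; its nearest neighbour is compound 1 and its furthest is compound 3, and both gaps lie within the scatter, so no order among these can be claimed.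

The unmeasured compound 4 `O=S(=O)(NCCCNc1nccc(-c2c(-c3cccc(F)c3)nc3sccn23)n1)c1ccccc1` differs from compound 2 in one place: ((phenylsulfonyl)amino)methyl in place of ((4-fluorophenyl)sulfonyl)amino on a saturated chain carbon, two bonds along the chain from a nitrogen on an aromatic ring. Among the compounds with values here, two measured steps bear on this. The step of a 1.3-fold higher number from compound 1 to compound 2 (0.13 log units; within the scatter) combines the same shift in chain length with a change of the halogen on the ring and stays within the scatter. The step of a 2.0-fold higher number from compound 2 to compound 3 (0.29 log units; within the scatter) shows that changing the halogen alone also stays within the scatter, while the step of a 2.6-fold higher number from compound 1 to compound 3 (0.42 log units; beyond the scatter) is only modest. Within the data shown here, no measured pair isolates the loss of the halogen by itself, and the chain change left no mark beyond the scatter. A step of a 1.2-fold lower number from compound 2 to compound 4 (0.07 log units; within the scatter) is therefore expected. The estimate for compound 4 is 8000 nM, with a range from 3500 nM to 18000 nM.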

Compound 4, half-maximal inhibitory concentration: 6600 nM
Compound 4: middle estimate off by 1.2-fold (0.08 log units), on the high side; measured number inside the range.
By their numbers in this assay, from the lowest: compounds 4, 1, 2 and 3 (each within the scatter of the next, the first and the last beyond it).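

Within the data shown here, compound 1 and compound 4 share the same longer chain and differ only on one aromatic carbon, so this pair gives the first look at the halogen by itself: with hydrogen in place of bromo, the result in this assay stays within the scatter (a 1.1-fold lower number from compound 1 to compound 4 (0.03 log units; within the scatter)), and here the halogen can go without a clear change. The two steps from the shorter chain then differ in outcome: the one starting from the fluoro compound stays within the scatter (a 1.4-fold lower number from compound 2 to compound 4 (0.16 log units; within the scatter)), whereas the one starting from the chloro compound goes modestly beyond it (a 2.8-fold lower number from compound 3 to compound 4 (0.45 log units; beyond the scatter)), and since that step alters chain and halogen together, its size cannot be assigned to either change. No measurement at hand explains any of these steps.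

What the chain does alone stays open, as every pair of compounds with different chains shown here also differs in the group on the aromatic ring. Also open, from the compounds shown here alone, is whether a longer chain, or a methoxy group on that aromatic carbon in place of the halogen, would move the number beyond the scatter.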